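This account rests on a few compounds, and the source may have more. Where it says the series, first, only, none or still open, it means among the compounds named here.

The measured compounds:
compound 1 `Cc1cccc(NS(=O)(=O)c2ccc(N3CCNC3=O)cc2)c1`: 190 nM
compound 2 `CCc1ccc(NS(=O)(=O)c2ccc(N3CCNC3=O)cc2)cc1`: 810 nM

In a functional assay on MCF7 cells (Homo sapiens) for antiproliferative activity, read by sulforhodamine B assay, with a stated time of 48 h (on this read-out higher numbers stand for weaker inhibition and lower numbers for stronger inhibition), compound 2 gives 810 nM, the highest of the two numbers recorded. Going by the values given here, its nearest neighbour is compound 1, which gives 190 nM, and the only measured step, a 4.3-fold higher number from compound 1 to compound 2 (0.63 log units; beyond the scatter), separates the two. Compound 3 `O=C1NCCN1c1ccc(S(=O)(=O)Nc2ccc(OC(F)F)cc2)cc1` keeps the shared core of compound 2 and differs from it in one place: difluoromethoxy in place of ethyl on an aromatic carbon. Among the compounds with values here, no measured step involves a difluoromethoxy group. Within the data shown here, the one step available exchanged one substituted phenyl for another on the sulfonamide nitrogen and was of modest size, so it bears on the present change only as an indication that a change of the group attached to that nitrogen can move the number by a modest amount; it gives no direction for compound 3. For compound 3 the expected step is therefore a 1.4-fold lower number from compound 2 to compound 3 (0.13 log units; within the scatter), which is estimated to stay within the scatter. Compound 3 is expected to give 600 nM, in a range from 200 nM to 2000 nM.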

Compound 3, half-maximal inhibitory concentration: 760 nM
Beside the measured number, compound 3's estimate is 1.3-fold (0.10 log units) below it; the measured number falls inside the stated range.
By their numbers in this assay, from the lowest: compound 1; then compounds 3 and 2 (each within the scatter of the next).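

At this aromatic carbon, para to a large group, the exchange of ethyl for difluoromethoxy gives a 1.1-fold lower number from compound 2 to compound 3 (0.03 log units; within the scatter) in this assay, so the oxygen, the fluorine atoms and the hydrogen-bond acceptor that enter with the new group leave the number within the scatter of that of compound 2. The earlier step, a 4.3-fold higher number from compound 1 to compound 2 (0.63 log units; beyond the scatter), had shown only that exchanging one substituted phenyl for another on the sulfonamide nitrogen can move the number beyond the scatter, whereas this pair shows that a change of the group alone at this one position need not do so. Nothing at hand explains why these two numbers stay together.

The compounds shown leave open whether an amine or a carboxylic acid on this same aromatic carbon would also stay within the scatter of compound 2, or whether the tolerance seen here holds only for ethyl and difluoromethoxy. They also leave open how much of the step between compound 1 and compound 2 belongs to the place of the group and how much to the group itself, as the two changed together in that pair.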